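The compounds below may be only part of what the source reports. "The series", "measured", "known", "first", "only" and "open" are said of these compounds alone.

Series in an ADME assay on MOLT-3 cells (Homo sapiens) for cytotoxicity, with a stated time of 7 days; a lower number here means that less compound is tolerated, a higher number that more compound is tolerated
Compound 1 `CNc1nc(N)nc2c1ncn2/C=C1/CC1(CO)CO` gives > 20000 nM
Compound 2 `CN(C)c1nc(N)nc2c1ncn2/C=C1/CC1(CO)CO` gives "not determined" (no result reported)
Compound 3 `CCCCCCOc1nc(N)nc2c1ncn2/C=C1/CC1(CO)CO` gives > 20000 nM
Compound 4 `CCCCOc1nc(N)nc2c1ncn2/C=C1/CC1(CO)CO` has no measurement yet

Compound 3 stands at > 20000 nM as a limit, not a number. Compound 1 also gives > 20000 nM as a limit. Compound 2 has no result. The change to compound 4 reads hydrogen in place of ethyl on a saturated chain carbon, four bonds along the chain from an oxygen on an aromatic ring and leaves the shared core untouched. Among the measured compounds shown here, the one measured step bearing on it is a step that the two limits leave unreadable from compound 1 to compound 3 and gives no size to carry over. For the measured compounds named here, the only other guide is the limit of > 20000 nM in this assay, at which 2 of the 3 values shown sit, for this series. No step beyond the scatter is therefore expected in this assay, and another limit is the likely report. The expected move is a step that the limit leaves unreadable from compound 3 to compound 4 on this reading. Compound 4 is estimated at 25000 nM with an expected range of 10000 nM to 60000 nM for a measured number.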

Compound 4, half-maximal cytotoxic concentration: > 20000 nM
Compound 4: no number, only a limit; the forecaster's own chance of this, stated with the estimate: 80%; the middle value is on the limit's open side.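

In this assay, among the compounds shown here, compound 1, compound 3 and compound 4 each stand only as a limit, so no step between them can be read. The compounds shown leave open whether methylamino, butoxy and hexyloxy differ at all in cytotoxicity.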